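The compounds below may be only part of what the source reports. "The series", "measured", "known", "first", "only" and "open" are said of these compounds alone.

Of the compounds shown here, two with a shared core have been measured in a physicochemical assay, read by spectrophotometry, with a stated time of 6 min; on this read-out lower numbers stand for stronger inhibition and higher numbers for weaker inhibition. Compound 1 `O=C(CCc1nc2ccccc2c(=O)[nH]1)N/N=C/c1ccc(O)cc1` carries a 4-hydroxyphenyl group on its hydrazone end and gives 105000000 nM in this assay. Compound 2 `COc1cc(/C=N/NC(=O)CCCc2nc3ccccc3c(=O)[nH]2)cc(OC)c1OC` differs from compound 1 both in the length of its chain and in the groups on its outer ring; compound 2 gives 60000000 nM. Of the two numbers, that of compound 1 is the higher, but the gap to compound 2 lies within the scatter of repeated measurements, so the two compounds cannot be told apart on these data alone.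

Compound 3 `COc1cc(/C=N/NC(=O)CCc2nc3ccccc3c(=O)[nH]2)ccc1O` has not yet been measured. It differs from compound 1 by a single change: methoxy in place of hydrogen on an aromatic carbon. For the measured compounds named here, no pair of measured compounds differing in exactly one place is available to anchor how large a shift this kind of change brings, so the expectation rests on the two values above and on the smallness of the change. For compound 3 the step from compound 1 is expected to stay close to nothing beyond the scatter, at about a 1.3-fold lower number from compound 1 to compound 3 (0.12 log units; within the scatter). Compound 3 is therefore estimated at 80000000 nM, with a likely range from 30000000 nM to 200000000 nM in this assay.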

Compound 3, half-maximal inhibitory concentration: 95000000 nM
Beside the measured number, compound 3's estimate is 1.2-fold (0.07 log units) below it; the range from low to high includes it.
By their numbers in this assay, from the lowest: compounds 2, 3 and 1 (each within the scatter of the next).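

For the compounds shown here, putting a methoxy group in place of hydrogen, which turns 4-hydroxyphenyl into 4-hydroxy-3-methoxyphenyl, gives the first comparison here between two compounds that differ in only one place, and in this assay it reads as a 1.1-fold lower number from compound 1 to compound 3 (0.04 log units; within the scatter) so compound 1 and compound 3 cannot be told apart. For this aromatic carbon, ortho to a hydroxy group and meta to a large group, the result therefore shows that this read-out does not separate methoxy from hydrogen, something that compound 1 and compound 2 could not show because they differ in both chain length and outer-ring groups. No supporting measurement is available to explain this result.

A single step cannot show whether an amine, a carboxylic acid or a bulkier ethoxy group on the same aromatic carbon would move the number beyond the scatter. Going by these compounds, it also remains open what a longer chain alone would do if the 4-hydroxyphenyl group of compound 1 were kept, since compound 2 alters the outer ring as well.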